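This account rests on a few compounds, and the source may have more. Where it says the series, first, only, none or still open, it means among the compounds named here.

Among the three numbers known so far in a functional assay on HT-29 cells (Homo sapiens) for cytotoxicity, read by MTT assay, with a stated time of 72 h (a higher number here means a weaker inhibitor, a lower number a stronger inhibitor), the lowest belongs to compound 1 (`Cc1ccc(NC(=O)CN2CCN(c3nnc(Cc4ccncc4)c4ccccc34)CC2)c(C)c1`) at 1930 nM and the next to compound 2 (`O=C(CN1CCN(c2nnc(Cc3ccccc3)c3ccccc23)CC1)Nc1ccc(F)c(C(F)(F)F)c1`) at 4590 nM, while compound 3 (`Cc1ccccc1NC(=O)CN1CCN(c2nnc(Cc3ccccc3)c3ccccc23)CC1`) is highest at 113000 nM on this scale. Compound 4 (`O=C(CN1CCN(c2nnc(Cc3ccncc3)c3ccccc23)CC1)Nc1ccc(F)c(Cl)c1`) keeps the core of compound 1 and changes one group, with 3-chloro-4-fluorophenyl in place of 2,4-dimethylphenyl on an amide-type nitrogen.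

Going by the values given here, only one measured step concerns a swap of this kind. Putting 2-methylphenyl in place of 4-fluoro-3-(trifluoromethyl)phenyl on an amide-type nitrogen gives a 25-fold higher number from compound 2 to compound 3 (1.39 log units; beyond the scatter) and counts as large. Read backwards, that step hints that the group in compound 4, which shares the 4-fluoro part of its name with the group in compound 2, could lower the number. Compound 1 goes against this reading, since it carries a dimethylphenyl group and still has the lowest number (1930 nM). Compounds 2 and 3 also differ from compound 1 elsewhere in the structure, so the large step cannot be carried over in full.

The estimated 1.5-fold lower number from compound 1 to compound 4 (0.17 log units; within the scatter) is therefore a small downward move that stays inside the usual scatter. The estimated value for compound 4 is 1300 nM (expected range from 350 nM to 5500 nM).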

Compound 4, half-maximal inhibitory concentration: 880 nM
Compound 4: middle estimate off by 1.5-fold (0.17 log units), on the high side; low and high end bracket the measured number.
By their numbers in this assay, from the lowest: compound 4; then compound 1; then compound 2; then compound 3.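

In this assay, going by these compounds alone, replacing 2,4-dimethylphenyl with 3-chloro-4-fluorophenyl on the amide-type nitrogen gives a 2.2-fold lower number from compound 1 to compound 4 (0.34 log units; beyond the scatter), the first direct reading of a change at this position with the core of compound 1 held constant. The two groups have the same heavy-atom count and the same single carbon-only aromatic ring, so the step reflects replacing two methyl groups with a chlorine and a fluorine, and it shows that this position can move the number on this core as well as on the core shared by compounds 2 and 3, where a different swap gave a 25-fold higher number from compound 2 to compound 3 (1.39 log units; beyond the scatter). Nothing measured here explains why the number falls.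

Chlorine and fluorine enter together, so the compounds shown cannot say whether one of them alone would account for the step, or whether removing the two methyl groups matters more. On these data alone, it also remains open how this position would respond to an unsubstituted phenyl group, or to a phenyl ring carrying a methoxy group, a nitrile or an amine.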